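The source may hold more compounds than are shown below. What is called first, only, known or untested is meant among the compounds shown, and "the series" means these compounds.

Working notes on the dithiocarbamate series. Of the compounds shown here, two have numbers so far. Compound 1 is `Nc1ccccc1NC(=O)c1ccc(CSC(=S)N2CCN(C(c3ccccc3)c3ccccc3)CC2)cc1` and compound 2 is `CN(C(=S)SCc1ccc(C(=O)Nc2ccccc2N)cc1)c1cccnc1`; both were run in a functional assay on HeLa cells (Homo sapiens) for antiproliferative activity, read by CCK-8 assay, with a stated time of 72 h, tested at 8 uM; a higher number here means a stronger effect of the compound at the concentration tested, a lower number a weaker effect. In this assay compound 1 gives 13.8%, and compound 2 gives 70.5%. Compound 2 therefore stands highest of the two measured numbers, and the gap to compound 1 is well beyond the scatter, so the amine on the thiocarbonyl carbon clearly matters here.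

The next member is compound 3, `CC1CCN(C(=S)SCc2ccc(C(=O)Nc3ccccc3N)cc2)CC1`. Relative to compound 2 it differs in one place: 4-methylpiperidin-1-yl in place of methyl(pyridin-3-yl)amino on a thiocarbonyl carbon. For the measured compounds named here, no measured pair covers this kind of exchange, so the expectation rests on the two numbers above only. Given that compound 1 with its own saturated ring on the thiocarbonyl carbon gives 13.8%, a drop from compound 2 is expected; the step from compound 2 to compound 3 is estimated at a number 28.5 percentage points lower from compound 2 to compound 3 (beyond the scatter), a fall beyond the scatter but not all the way down to the level of compound 1. Compound 3 is expected to give 42% in this assay, with a range from 18% to 66%.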

Compound 3, a percentage reported as inhibition, at one concentration (the size of the read-out at that concentration, not a potency): 72.5%
Estimate against measurement, compound 3: 30.5 percentage points below, and the stated range ends below it.
By their numbers in this assay, from the lowest: compound 1; then compounds 2 and 3 (each within the scatter of the next).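

In this assay, 4-methylpiperidin-1-yl in place of methyl(pyridin-3-yl)amino on a thiocarbonyl carbon gives a number 2 percentage points higher from compound 2 to compound 3 (within the scatter), so this position accepts a six-membered non-aromatic ring as well as the six-membered aromatic ring carried on the nitrogen of the group that leaves. A non-aromatic ring on this carbon therefore does not by itself go with a low read-out: compound 3 gives 72.5%, whereas compound 1, which also carries a non-aromatic ring there, gives 13.8%, and what separates these two remains unresolved. No measurement at hand explains why the two groups in compound 2 and compound 3 read alike.

Still open, as far as these compounds go, is whether the methyl of 4-methylpiperidin-1-yl contributes at all, which a plain piperidin-1-yl would address, and how a morpholin-4-yl or a small dimethylamino group would read on the same carbon. From the compounds shown here alone, each read-out also comes from a single concentration, so whether compound 2 and compound 3 would separate in potency remains unknown.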